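A methoxypyridine replaces the ring oxide in compound 2

The source may hold more compounds than are shown below. What is called first, only, known or untested is meant among the compounds shown, and "the series" means these compounds.

Measured so far:
compound 1, `C[C@@H](O[C@H]1CN2C(=O)C=C(c3ccc(F)cc3)CC2[C@@H]1c1ccc(F)cc1)c1cc(C(F)(F)F)cc(C(F)(F)F)c1`, 100 nM
compound 2, `C[C@@H](O[C@H]1CN2C(=O)C=C(c3cc[n+]([O-])cc3)CC2[C@@H]1c1ccc(F)cc1)c1cc(C(F)(F)F)cc(C(F)(F)F)c1`, 2.1 nM

Both compounds were tested in an assay on CHO cells for displacement of a labelled ligand from Substance-P receptor (Homo sapiens), in the presence of a further agent that is not named here; on this read-out higher numbers stand for weaker inhibition and lower numbers for stronger inhibition. Compound 2 has the lower of the two numbers: the change from compound 1 to compound 2, where the fluorophenyl ring on the double-bonded ring carbon gave way to a six-membered aromatic ring with one hetero atom, produced a 48-fold lower number from compound 1 to compound 2 (1.68 log units; beyond the scatter).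

Compound 3, `COc1cc(C2=CC(=O)N3C[C@H](O[C@H](C)c4cc(C(F)(F)F)cc(C(F)(F)F)c4)[C@@H](c4ccc(F)cc4)C3C2)ccn1`, has not been measured. Its change from compound 2 is a group of 8 heavy atoms (6 carbon, 1 nitrogen, 1 oxygen; one six-membered aromatic ring with 1 hetero atom) in place of a group of 7 heavy atoms (5 carbon, 1 nitrogen, 1 oxygen; one six-membered aromatic ring with 1 hetero atom), on a double-bonded ring carbon. For the measured compounds named here, no measured step covers this exact exchange; the only step known, from compound 1 to compound 2, swapped a carbon-only ring for a hetero ring and was large, whereas here one hetero ring stands in for another at the same position. With nothing directly comparable, the safest expectation is a number near that of compound 2, with some risk of a modest rise. The expected step from compound 2 to compound 3 in this assay is therefore a 2.4-fold higher number from compound 2 to compound 3 (0.38 log units; beyond the scatter). For compound 3 the estimate in this assay is 5 nM, with a plausible range from 1.5 nM to 20 nM.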

Compound 3, half-maximal inhibitory concentration: 44 nM
Estimate against measurement, compound 3: 8.8-fold (0.94 log units) below, outside the stated range (above it).
By their numbers in this assay, from the lowest: compound 2; then compound 3; then compound 1.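

In this assay, the position on the double-bonded ring carbon turns out to respond to far more than the mere presence of a hetero ring: exchanging the ring oxide for 2-methoxypyridin-4-yl gave a 21-fold higher number from compound 2 to compound 3 (1.32 log units; beyond the scatter) even though each group holds one six-membered aromatic ring with 1 hetero atom. Set against 4-fluorophenyl, the same 2-methoxypyridin-4-yl group gave only a 2.3-fold lower number from compound 1 to compound 3 (0.36 log units; beyond the scatter) and so keeps just a small part of the large gain that compound 2 shows over compound 1, which means that among these three compounds a ring nitrogen does not by itself bring the full gain. Nothing available here explains why these two hetero rings differ so much.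

The compounds shown leave open whether the loss in compound 3 goes with the absence of the ring oxide or with the presence of the methoxy group, and the plain pyridin-4-yl ring would help to separate the two. Going by these compounds, it also remains open whether 2-aminopyridin-4-yl or 2-methylpyridin-4-yl would give a number closer to that of compound 2 or to that of compound 1.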